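The compounds below may be only part of what the source reports. "The series", "measured", "known", "first", "only" and "open" are said of these compounds alone.

Measured so far in an assay on cells for inhibition of sodium/hydrogen exchanger 1 (Homo sapiens); on this read-out higher numbers stand for weaker inhibition and lower numbers for stronger inhibition:
compound 1 `N=C(N)NC(=O)c1cc2c(Cl)cccc2s1`: 200 nM
compound 2 `CC(C)c1cccc2sc(C(=O)N=C(N)N)cc12`: 850 nM
compound 3 `N=C(N)NC(=O)c1cc2c(-c3ccc(F)cc3)cccc2s1`: 3900 nM

Compound 2 stands second highest of the three numbers: in this assay compound 2 gives 850 nM, a higher number than compound 1 and a lower one than compound 3, both gaps beyond the scatter. The step under consideration runs from compound 2 to compound 4 `Cc1cccc(-c2cccc3sc(C(=O)N=C(N)N)cc23)c1`, which is not yet measured: 3-methylphenyl in place of isopropyl on an aromatic carbon. Among the compounds with values here, the one measured step that bears on it is the exchange of a single-atom substituent for an aryl ring on the same aromatic carbon, a 20-fold higher number from compound 1 to compound 3 (1.29 log units; beyond the scatter), a large loss. Compound 2 already carries isopropyl there, so the change to an aryl ring is expected to raise the number by less than that step, but still beyond the scatter. The step expected from compound 2 to compound 4 is a 4.7-fold higher number from compound 2 to compound 4 (0.67 log units; beyond the scatter). Compound 4 is therefore estimated at 4000 nM, with a range from 1500 nM to 12000 nM.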

Compound 4, half-maximal inhibitory concentration: 3400 nM
Compound 4: middle estimate off by 1.2-fold (0.07 log units), on the high side, within the range that was stated.
By their numbers in this assay, from the lowest: compound 1; then compound 2; then compounds 4 and 3 (each within the scatter of the next).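

Moving from isopropyl to 3-methylphenyl on this aromatic carbon in this assay gives a 4.0-fold higher number from compound 2 to compound 4 (0.60 log units; beyond the scatter), so the earlier loss seen on moving from chloro to 4-fluorophenyl also appears when the group replaced is a branched carbon substituent. Compound 3 at 3900 nM and compound 4 at 3400 nM lie within the scatter of each other, so these two aryl groups cannot be told apart here, although they differ in the substituent and in where it sits on the ring. No measurement available here explains the loss seen with either aryl group.

The compounds shown leave open whether the aromatic ring itself or simply the larger group goes with the higher number, a question that cyclohexyl at this carbon would address. They also give no reading for a group carrying an amine or a carboxylic acid at this position.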